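Methoxy for Fluoro in a Two-Compound Growth Series

The source may hold more compounds than are shown below. What is called first, only, known or untested is meant among the compounds shown, and "the series" means these compounds.

Compound 1, `COC(=O)[C@@]1(C)CCC=C2[C@@H]1CC[C@@H](C)[C@]2(C)Cc1c[nH]c2ccc(OC)cc12`, gives 5700 nM in a functional assay on WiDr cells (Homo sapiens) for inhibition, read by sulforhodamine B assay, with a stated time of 48 h; a lower number here means a stronger inhibitor of growth, a higher number a weaker inhibitor of growth.
Compound 2, `COC(=O)[C@@]1(C)CCC=C2[C@@H]1CC[C@@H](C)[C@]2(C)Cc1c(C)[nH]c2ccc(F)cc12`, gives 17000 nM in this assay.

Compound 2 stands at the higher of the two numbers, with compound 1 beyond the scatter below it. Among the compounds with values here, the two measured compounds differ in more than one place, so no single step joins them. Compound 3, `COC(=O)[C@@]1(C)CCC=C2[C@@H]1CC[C@@H](C)[C@]2(C)Cc1c(C)[nH]c2ccc(OC)cc12`, carries methoxy in place of fluoro on an aromatic carbon. Because compound 1 also bears the methoxy group and gives 5700 nM, a moderate drop in the number is expected, a 2.1-fold lower number from compound 2 to compound 3 (0.33 log units; beyond the scatter), though it may fall within the scatter. Compound 3 is estimated at 8000 nM, between 3000 nM and 25000 nM.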

Compound 3, concentration for 50% growth inhibition: 17000 nM
Compound 3: the middle estimate sits 2.1-fold (0.33 log units) below what was measured; the range from low to high includes it.
By their numbers in this assay, from the lowest: compound 1; then compounds 2 and 3 (each within the scatter of the next).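

In this assay, the methoxy in place of fluoro on this aromatic carbon gives no change at the digits printed from compound 2 to compound 3 (within the scatter), so with the methyl present the two groups cannot be told apart here. Within the data shown here, the only step that moves the number is the other one, methyl in place of hydrogen on an aromatic carbon, with a 3.0-fold higher number from compound 1 to compound 3 (0.47 log units; beyond the scatter) in the methoxy compounds. Nothing given here explains either step. As far as these compounds go, whether fluoro and methoxy also match without the methyl remains open, as does how an amine or a carboxylic acid on that aromatic carbon would read.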